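From ethynyl to phenyl: a small expected step

The compounds below may be only part of what the source reports. "The series", "measured", "known", "first", "only" and "open" are said of these compounds alone.

Measured so far in an ADME assay on WI-38 cells (Homo sapiens) for cytotoxicity, read by MTT assay, with a stated time of 72 h; a higher number here means a weaker inhibitor, a lower number a stronger inhibitor:
- Compound 1 `O=C(CCc1cccc2c1B(O)OC2)Nc1cccc(I)c1` gives 71000 nM
- Compound 2 `C#Cc1cccc(NC(=O)CCc2cccc3c2B(O)OC3)c1` gives > 100000 nM as a limit

Compound 2 has only a limit and no number, as the limit of > 100000 nM in this assay, at which 1 of the 2 values shown sits, shows. Compound 3 `O=C(CCc1cccc2c1B(O)OC2)Nc1cccc(-c2ccccc2)c1` differs from it by one change phenyl in place of ethynyl on an aromatic carbon which puts phenyl in place of ethynyl on an aromatic carbon. Going by the values given here, the only measured step also exchanges a group on an aromatic carbon and is an at least 1.4-fold higher number from compound 1 to compound 2 (0.14 log units; that floor lies within the scatter) so no step beyond the scatter is expected in this assay in either direction. The expected change is an at least 1.1-fold lower number from compound 2 to compound 3 (0.04 log units; that floor lies within the scatter) and no larger. For compound 3 the estimate is 90000 nM with an expected range from 40000 nM to 200000 nM in this assay.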

Compound 3, half-maximal inhibitory concentration: 12000 nM
Estimate against measurement, compound 3: 7.5-fold (0.88 log units) above; the measured number lies below the stated range.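

In this assay this position turns out to respond to what sits on it, which the swap of iodo for ethynyl did not show beyond the scatter. Phenyl gives an at least 8.3-fold lower number from compound 2 to compound 3 (0.92 log units; beyond the scatter) and also a 5.9-fold lower number from compound 1 to compound 3 (0.77 log units; beyond the scatter) so both neighbours lead to the same direction of change. The first of these steps starts from a limit and not a number: the limit of > 100000 nM in this assay, at which 1 of the 3 values shown sits.

Going by these compounds, whether the aromatic ring itself or simply the larger group goes with the lower number stays open. A cyclohexyl group at this place, or an amine on the added phenyl, would bear on that.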